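Chloro for fluoro on the aromatic ring of compound 3

The compounds below may be only part of what the source reports. "The series", "measured", "known", "first", "only" and "open" are said of these compounds alone.

Compound 3 `N[C@]1(C(=O)O)[C@H]2[C@@H](C[C@H]1OCc1ccc(F)c(F)c1)[C@]2(F)C(=O)O` gives the lowest number of the three compounds measured in an assay on CHO cells for binding affinity to metabotropic glutamate receptor 2 (Rattus norvegicus) (on this read-out lower numbers stand for stronger inhibition and higher numbers for weaker inhibition), at 2.27 nM. Compound 1 `CCC(C)O[C@@H]1C[C@@H]2[C@H]([C@]1(N)C(=O)O)[C@@]2(F)C(=O)O` gives 6.68 nM in this assay, and compound 2 `N[C@]1(C(=O)O)[C@H]2[C@@H](C[C@H]1OCc1cccc(-c3ccccc3)c1)[C@]2(F)C(=O)O` gives 9.34 nM in this assay; both gaps to compound 3 lie beyond the usual scatter, so compound 3 is the strongest binder of the measured set. Compound 4 `N[C@]1(C(=O)O)[C@H]2[C@@H](C[C@H]1OCc1ccc(F)c(Cl)c1)[C@]2(F)C(=O)O` is not yet measured. It differs from compound 3 in one place: chloro in place of fluoro on an aromatic carbon. The fluoro that leaves sits on an aromatic carbon of a six-membered aromatic ring of carbon only, ortho to a fluoro group and meta to a large group, and the chloro that enters takes that same carbon. Within the data shown here, no pair of measured compounds isolates this change, so nothing measured here speaks to it directly. A small step is expected in this assay, most likely within the scatter and without a clear direction. Compound 4 is estimated at 2.5 nM, with a range of 1 nM to 6 nM. The step of a 1.1-fold higher number from compound 3 to compound 4 (0.04 log units; within the scatter) is expected to stay within the scatter.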

Compound 4, inhibition constant: 3.57 nM
For compound 4 the middle estimate is 1.4-fold (0.15 log units) below the measured one; low and high end bracket the measured number.
By their numbers in this assay, from the lowest: compounds 3, 4, 1 and 2 (each within the scatter of the next, the first and the last beyond it).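

Among these compounds, on the 3,4-difluorophenyl group, chloro in place of fluoro gives a 1.6-fold higher number from compound 3 to compound 4 (0.20 log units; within the scatter) in this assay, and this is the only measured pair that isolates a single change. This aromatic carbon therefore carries either fluoro or chloro without a difference that can be told from the scatter, so 3-chloro-4-fluorophenyl serves here as well as 3,4-difluorophenyl. Nothing at hand explains this tolerance or ties it to any property of the two halogens.

Still open, on these data alone, is how bromo, methyl, methoxy or a nitrile on this same carbon would compare with chloro. Also open, as far as these compounds go, is how binding would respond to replacing the fluoro that compound 3 and compound 4 share on the aromatic ring.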